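Fluoro for methoxy on compound 3

The source may hold more compounds than are shown below. What is called first, only, known or untested is meant among the compounds shown, and "the series" means these compounds.

Measured so far in an ADME assay on MT4 cells (Homo sapiens) for cytotoxicity, read by MTT assay, with a stated time of 4 days (a higher number here means that more compound is tolerated, a lower number that less compound is tolerated), are three compounds:
compound 1 `COc1cccc(-c2oc3ccc(NC(C)=O)cc3c(=O)c2O)c1` with 33300 nM
compound 2 `CC(=O)Nc1ccc2oc(-c3cccc(F)c3)c(O)c(=O)c2c1` with 26500 nM
compound 3 `COc1cccc(-c2oc3ccc(NC(C)=O)cc3c(=O)c2OC)c1` with 369000 nM

Compound 3 holds the highest of these numbers, beyond the scatter from both others. Compound 4 `COc1c(-c2cccc(F)c2)oc2ccc(NC(C)=O)cc2c1=O` has not been measured yet. It differs from compound 3 in one place fluoro in place of methoxy on an aromatic carbon and carries fluoro in place of methoxy on an aromatic carbon. The same exchange has been measured once, as a 1.3-fold lower number from compound 1 to compound 2 (0.10 log units; within the scatter), without the methyl on the oxygen. The other measured step, an 11-fold higher number from compound 1 to compound 3 (1.04 log units; beyond the scatter), was large, but it is a different change and does not recur here. No step beyond the scatter is therefore expected, and the expected change is a 1.2-fold lower number from compound 3 to compound 4 (0.09 log units; within the scatter), slightly downward. Compound 4 is estimated at 300000 nM (130000 nM to 650000 nM).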

Compound 4, half-maximal cytotoxic concentration: 210000 nM
Beside the measured number, compound 4's estimate is 1.4-fold (0.15 log units) above it, and the stated range covers the measured number.
By their numbers in this assay, from the lowest: compounds 2 and 1 (each within the scatter of the next); then compounds 4 and 3 (each within the scatter of the next).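

Fluoro in place of methoxy gives a 1.8-fold lower number from compound 3 to compound 4 (0.24 log units; within the scatter) in this assay, so this position changes little with the methyl on the oxygen as well as without it: the same change on two cores in this assay, a 1.3-fold lower number (0.10 log units; within the scatter) from compound 1 to compound 2 and a 1.8-fold lower number (0.24 log units; within the scatter) from compound 3 to compound 4, 1.4-fold (0.15 log units) apart, within the scatter of two such steps. Methyl in place of hydrogen on the oxygen, so far seen only with 3-methoxyphenyl, also holds with 3-fluorophenyl, giving a 7.9-fold higher number from compound 2 to compound 4 (0.90 log units; beyond the scatter): the same change on two cores in this assay, an 11-fold higher number (1.04 log units; beyond the scatter) from compound 1 to compound 3 and a 7.9-fold higher number (0.90 log units; beyond the scatter) from compound 2 to compound 4, 1.4-fold (0.15 log units) apart, within the scatter of two such steps. Going by these compounds, only methoxy and fluoro stand at the first position, so whether an amine or a carboxylic acid there would behave alike remains open. Also open, on these data alone, is whether a longer chain on the oxygen would give a similar step.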